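Swapping the Amide Substituent on a Shared Core

A few compounds are considered here, and "the series" means these few. Any claim that something is new, unique, unknown or untested is made for them only; others in the source may bear on it.

Compound 1 `O=C(/C=C1\CCc2c(F)cc(F)cc21)NCCO` was tested in a functional assay on the whole organism with Mus musculus as the target (a lower number here means that less compound is needed, a higher number that more compound is needed for the effect), and gives 100 mg/kg. For the measured compounds named here, of the two numbers known so far this is the lowest, yet compound 2 `O=C(/C=C1\CCc2ccccc21)NC1CC1`, which gives 150 mg/kg in this assay, sits within the usual scatter of it, so the two cannot be ranked. Compound 3 `O=C(/C=C1\CCc2c(F)cc(F)cc21)NC1CC1` has not yet been measured in this assay. It differs from compound 1 in one place: cyclopropyl in place of 2-hydroxyethyl on an amide-type nitrogen. Going by the values given here, no pair of measured compounds follows this same change, so there is no direction to borrow. Compound 2 does carry a cyclopropyl on an amide-type nitrogen and gives 150 mg/kg, a number within the scatter of compound 1, which hints that the change weighs little here. The expected step of a 1.2-fold higher number from compound 1 to compound 3 (0.08 log units; within the scatter) is therefore none beyond the scatter. Compound 3 is estimated to give 120 mg/kg in this assay, with a range from 60 mg/kg to 250 mg/kg.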

Compound 3, dose for half-maximal effect: 62 mg/kg
Compound 3: middle estimate off by 1.9-fold (0.29 log units), on the high side; the measured number falls inside the stated range.
By their numbers in this assay, from the lowest: compounds 3, 1 and 2 (each within the scatter of the next, the first and the last beyond it).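

For the compounds shown here, on the shared core, this is the first direct test of the group on the amide-type nitrogen: in this assay, replacing 2-hydroxyethyl with cyclopropyl gives a 1.6-fold lower number from compound 1 to compound 3 (0.21 log units; within the scatter). An open chain with one hydrogen-bond donor and one hydrogen-bond acceptor gives way to a three-membered ring with neither, yet the two compounds cannot be told apart, so in this pair the assay does not register the change at this position. No measured evidence bears on why this is so.

As far as these compounds go, whether a longer chain, an amine or a carboxylic acid on this nitrogen would also stay within the scatter remains open. The compounds shown also cannot tell whether the same swap would give a similarly small step on a different core.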